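A few compounds are considered here, and "the series" means these few. Any claim that something is new, unique, unknown or untested is made for them only; others in the source may bear on it.

Compound 2 `CN(C)c1ccc(C2CC(c3ccc(-n4cncn4)cc3)=NN2S(=O)(=O)c2ccc(F)cc2)cc1` gives 24.1% in a functional assay on HCC1806 cells (Homo sapiens) for inhibition, read by sulforhodamine B assay, tested at 10 uM (on this read-out lower numbers stand for less inhibition and higher numbers for more inhibition at the one concentration tested (going by the name of the read-out)), the lower of the two numbers shown, though this difference to compound 1 lies within the scatter. Compound 1 `Cc1ccc(S(=O)(=O)N2N=C(c3ccc(-n4cncn4)cc3)CC2c2ccc(N(C)C)cc2)cc1` gives 27.7% in this assay, and the step of a number 3.6 percentage points lower from compound 1 to compound 2 (within the scatter) stays within the scatter. Compound 3 `CN(C)c1ccc(C2CC(c3ccc(-n4cncn4)cc3)=NN2S(=O)(=O)c2ccc(C(F)(F)F)cc2)cc1` differs from compound 2 by trifluoromethyl in place of fluoro on an aromatic carbon. For the measured compounds named here, the only measured step that bears on this change sits at the same aromatic carbon, namely a number 3.6 percentage points lower from compound 1 to compound 2 (within the scatter), and it did not move beyond the scatter. Compound 3 is therefore expected to show a step of a number 0.9 percentage points higher from compound 2 to compound 3 (within the scatter), nothing beyond the scatter. The estimate for compound 3 in this assay is 25%, with a range from 12% to 40%.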

Compound 3, a percentage reported as inhibition, at one concentration (the size of the read-out at that concentration, not a potency): 37%
Beside the measured number, compound 3's estimate is 12 percentage points below it; low and high end bracket the measured number.
By their numbers in this assay, from the lowest: compounds 2, 1 and 3 (each within the scatter of the next, the first and the last beyond it).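

In this assay, for the compounds shown here, the change from 4-fluorophenyl to 4-(trifluoromethyl)phenyl gives a number 12.9 percentage points higher from compound 2 to compound 3 (beyond the scatter) and is the only step at this aromatic carbon to pass the scatter, whereas a number 9.3 percentage points higher from compound 1 to compound 3 (within the scatter) does not. The position therefore responds to the group it carries, but only modestly, and only the fluoro and trifluoromethyl pair stands apart. Nothing in the available data explains this step. Going by these compounds, what an amine, a carboxylic acid or a methoxy group at this carbon would give remains open.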